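The source may report more compounds than this note shows. Statements on the series, on what has been measured and on what is new or still open speak of the compounds shown alone.

Compound 1 `COc1ccc(-c2nsc3c2NC(=O)CC3c2cccc(OC)c2)cc1`: 1390 nM
Compound 2 `COc1ccc(-c2nsc3c2NC(=O)CC3c2ccc3c(c2)OCCO3)cc1`: 1710 nM

In a functional assay on MDA-MB-231 cells (Homo sapiens) for antiproliferative activity, read by CellTiter-Glo, with a stated time of 96 h (a higher number here means a weaker inhibitor, a lower number a stronger inhibitor), compound 1 and compound 2 lie within the usual scatter of each other, so these numbers do not rank them. Compound 3 `COc1ccc(-c2nsc3c2NC(=O)CC3c2cccc(Cl)c2)cc1` has not yet been measured. It differs from compound 1 by chloro in place of methoxy on an aromatic carbon, meta to a large group: chloro in place of methoxy on an aromatic carbon. For the measured compounds named here, no measured pair shows this change, so no step beyond the scatter is expected in this assay. The expected step is a 1.3-fold lower number from compound 1 to compound 3 (0.10 log units; within the scatter). Compound 3 is estimated at 1100 nM, with an expected range of 450 nM to 3000 nM.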

Compound 3, half-maximal inhibitory concentration: 1620 nM
For compound 3 the middle estimate is 1.5-fold (0.17 log units) below the measured one; the range from low to high includes it.
By their numbers in this assay, from the lowest: compounds 1, 3 and 2 (each within the scatter of the next).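

In this assay the exchange of 3-methoxyphenyl for 3-chlorophenyl gives a 1.2-fold higher number from compound 1 to compound 3 (0.07 log units; within the scatter) and so shows that, at this position, a single chlorine atom can replace the methoxy group without a change these numbers can resolve. The methoxy oxygen, the only hydrogen-bond acceptor in the group that leaves, can therefore go with no measurable loss here. Nothing available explains this result. On these data alone, whether an amine, a carboxylic acid or a longer chain at this place would move the number beyond the scatter remains open.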